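The compounds below may be only part of what the source reports. "The series", "measured", "known", "first", "only" and "open" are said of these compounds alone.

Compounds measured in an ADME assay on PBMC cells (Homo sapiens) for cytotoxicity, with a stated time of 5 days; a lower number here means a stronger inhibitor, a higher number a weaker inhibitor:

- Compound 1 `C=CCNc1ncnc2c1ncn2[C@H]1C[C@H](N=[N+]=[N-])[C@@H](CO)O1`: 51100 nM
- Compound 2 `C=CCNc1nc(N)nc2c1ncn2[C@H]1C[C@H](N=[N+]=[N-])[C@@H](CO)O1`: > 100000 nM (a limit)
- Compound 3 `[N-]=[N+]=N[C@H]1C[C@H](n2cnc3c(N)nc(F)nc32)O[C@@H]1CO`: 30100 nM

Compound 2 gives only a limit, > 100000 nM, and not a number. It therefore has no exact place among the three compounds, and (the limit of > 100000 nM in this assay, at which 1 of the 3 values shown sits).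

Compound 4 `C=CCN(C)c1nc(N)nc2c1ncn2[C@H]1C[C@H](N=[N+]=[N-])[C@@H](CO)O1` has not yet been measured. It differs from compound 2 by methyl in place of hydrogen on a nitrogen on an aromatic ring, so that allylamino becomes allyl(methyl)amino.

For the measured compounds named here, the only measured step is an at least 1.9-fold higher number from compound 1 to compound 2 (0.29 log units; that floor lies within the scatter). That step is amino in place of hydrogen on an aromatic carbon, so it bears on the new change only indirectly. Going by the values given here, no measured step shows the methyl change itself. No step beyond the scatter is therefore expected, with a slight lean towards a lower number, as compound 1 gives 51100 nM.

The estimated change is an at least 1.2-fold lower number from compound 2 to compound 4 (0.09 log units; that floor lies within the scatter). For compound 4 the estimated value is 80000 nM, with an expected range from 30000 nM to 160000 nM.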

Compound 4, half-maximal inhibitory concentration: > 100000 nM
Compound 4 gave a limit, no number (the forecaster's own chance of this, stated with the estimate: 50%); middle value at least 1.2-fold (0.09 log units) away from the limit.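

Like compound 2, compound 4 gives only a limit (> 100000 nM), not a number, so no step can be read between compound 2 and compound 4: the limit of > 100000 nM in this assay, at which 2 of the 4 values shown sit. The compounds shown leave open whether allyl(methyl)amino in place of allylamino changes the value at all.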